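Benzyloxy swap on a second acylurea core

A few compounds are considered here, and "the series" means these few. Any claim that something is new, unique, unknown or untested is made for them only; others in the source may bear on it.

Compound 1 `Cc1ccc(COc2ccc(C(=O)NC(=S)Nc3ccc(C)c(-c4nc5ccccc5[nH]4)c3)cc2)cc1` and compound 3 `Cc1ccc(COc2ccc(C(=O)NC(=O)Nc3ccc(C)c(-c4nc5ccccc5[nH]4)c3)cc2)cc1` share much of their structure, but the difference between the two cores is not broken down here. In a functional assay on MNK45 cells (Homo sapiens) for inhibition, read by MTT assay, with a stated time of 48 h (on this read-out lower numbers stand for stronger inhibition and higher numbers for weaker inhibition), compound 1 gives 11300 nM, and compound 3 gives 6360 nM; these two values lie within the scatter of each other, so no order between them is read. Compound 2 `Cc1ccc(NC(=S)NC(=O)c2ccc(OCc3cccc(F)c3)cc2)cc1-c1nc2ccccc2[nH]1` is obtained from compound 1 by 3-fluorophenyl in place of 4-methylphenyl on a saturated chain carbon bound to an oxygen on an aromatic ring. In this assay compound 2 gives 86800 nM; the step is a 7.7-fold higher number from compound 1 to compound 2 (0.89 log units; beyond the scatter). Compound 4 `Cc1ccc(NC(=O)NC(=O)c2ccc(OCc3cccc(F)c3)cc2)cc1-c1nc2ccccc2[nH]1` stands to compound 3 as compound 2 stands to compound 1: the change is 3-fluorophenyl in place of 4-methylphenyl on a saturated chain carbon bound to an oxygen on an aromatic ring, at the same place, so it is the same change carried onto the core of compound 3. Compound 4 has not yet been measured in this assay. Only one measured instance of this change is shown, and it sits on a core whose difference from that of compound 3 is not broken down, so its size is taken over as a guide rather than as a rule. Among the compounds with values here, for compound 4 the step of a 6.3-fold higher number from compound 3 to compound 4 (0.80 log units; beyond the scatter) is expected, set beside a 7.7-fold higher number from compound 1 to compound 2 (0.89 log units; beyond the scatter), because a 7.7-fold higher number from compound 1 to compound 2 (0.89 log units; beyond the scatter) is the sole measured instance of the change. Compound 4 is therefore estimated at 40000 nM in this assay, with the expected range running from 12000 nM to 150000 nM to allow for a single precedent on a different core.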

Compound 4, half-maximal inhibitory concentration: 53000 nM
Estimate against measurement, compound 4: 1.3-fold (0.12 log units) below; low and high end bracket the measured number.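

In this assay, 3-fluorobenzyl in place of 4-methylbenzyl gives an 8.3-fold higher number from compound 3 to compound 4 (0.92 log units; beyond the scatter), so the change carries onto the core of compound 3 with a size that matches its earlier instance: the same change on two cores in this assay, a 7.7-fold higher number (0.89 log units; beyond the scatter) from compound 1 to compound 2 and an 8.3-fold higher number (0.92 log units; beyond the scatter) from compound 3 to compound 4, 1.1-fold (0.04 log units) apart, within the scatter of two such steps

Within this small set, the step measured on one core would therefore have served as a fair guide to the step on the other, and the difference between the two cores does not visibly alter the size of this change. Within the data shown here, this rests on only two pairs, one pair of groups and a single cell read-out, so it sets no rule for a third core or for any other replacement at this place, and it does not show why the number rises.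

Both steps remove the methyl and introduce the fluorine together, so the compounds shown leave open how much of the rise belongs to the loss of 4-methylphenyl and how much to the arrival of 3-fluorophenyl. An unsubstituted benzyl on the same oxygen would help separate the two, while an amine or a carboxylic acid on that ring, or a longer chain in place of the benzyl carbon, would test how far the parallel between the two cores extends.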